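Swapping fluoro for ethoxy on an active nucleoside

A few compounds are considered here, and "the series" means these few. Any claim that something is new, unique, unknown or untested is made for them only; others in the source may bear on it.

Measured in a functional assay on HEp-2 cells (Homo sapiens) for cytotoxicity; on this read-out higher numbers stand for weaker inhibition and lower numbers for stronger inhibition:
- Compound 1 `CSc1nc(N)c2nnn(C3O[C@H](CO)[C@@H](O)[C@H]3O)c2n1`: > 130000 nM (a limit of the assay, not a number)
- Compound 2 `Nc1nc(F)nc2c1nnn2C1O[C@H](CO)[C@@H](O)[C@H]1O`: 2000 nM

Among the measured compounds shown here, compound 2 is the only compound here with an actual number, so it has no numeric neighbour to be ranked against. Compound 3 `CCOc1nc(N)c2nnn(C3O[C@H](CO)[C@@H](O)[C@H]3O)c2n1` differs from it by ethoxy in place of fluoro on an aromatic carbon. For the measured compounds named here, one measured step bears on this place: an at least 65-fold lower number from compound 1 to compound 2 (1.81 log units; beyond the scatter), a large one, with fluoro in place of methylsulfanyl on an aromatic carbon. Fluoro leaves again here, so a large step towards weaker inhibition is expected in this assay, though this rests on that single step. The estimated step is a 40-fold higher number from compound 2 to compound 3 (1.60 log units; beyond the scatter). For compound 3 the expected value is 80000 nM, with an estimated range of 15000 nM to 300000 nM.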

Compound 3, half-maximal inhibitory concentration: > 75000 nM
Compound 3 gave a limit, no number; the forecaster's own chance of this, stated with the estimate: 55%; the middle value does not contradict the limit.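

In this assay, a second, different group now replaces fluoro on the aromatic carbon between two ring nitrogen atoms, and inhibition again weakens sharply: an at least 37-fold higher number from compound 2 to compound 3 (1.57 log units; beyond the scatter). Compound 3 gives > 75000 nM, which is a limit of the assay and not a number. Compound 1 also gives a limit, so the step between compound 1 and compound 3 cannot be read, and among these three groups only fluoro yields a number. Going by these compounds, it remains open whether fluoro alone gives this inhibition on that carbon. A chloro group or an amine there would show how other groups compare.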